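Aryl variation on the chain carbon of the thiazole-4-yl sulfonamide series

The source may report more compounds than this note shows. Statements on the series, on what has been measured and on what is new or still open speak of the compounds shown alone.

Measured so far:
- compound 1 `CCC(c1ccccc1)N(C)c1ccc(S(=O)(=O)Nc2nccs2)cc1Cl`: 1410 nM
- compound 2 `C[C@H](Nc1cc(F)c(S(=O)(=O)Nc2nccs2)cc1Cl)c1ccccc1`: 20 nM
- compound 3 `C[C@H](Nc1cc(F)c(S(=O)(=O)Nc2cscn2)cc1Cl)c1ccccc1`: 650 nM

All values come from an assay on HEK293 cells for inhibition of SCN8A/SCN1B (Homo sapiens), read by patch clamp, with a stated time of 20 min; a lower number here means a stronger inhibitor, a higher number a weaker inhibitor. Among the three measured compounds, compound 3 sits second highest; compound 1 gives a somewhat higher number and compound 2 a far lower one. Among the compounds with values here, the one step that is fully defined, a 33-fold higher number from compound 2 to compound 3 (1.51 log units; beyond the scatter), swaps the thiazole isomer on the sulfonamide nitrogen and is large.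

Compound 4 `COc1ccc(F)c([C@H](C)Nc2cc(F)c(S(=O)(=O)Nc3cscn3)cc2Cl)c1` keeps the whole core of compound 3 and alters only the aryl group on the chain: 2-fluoro-5-methoxyphenyl in place of phenyl on a saturated chain carbon bound to a nitrogen on an aromatic ring and a saturated chain carbon. Within the data shown here, none of the measured steps touches this chain aryl group; compound 1 carries a phenyl too, but differs from compounds 2 and 3 in several places at once, so its value does not isolate this change. Among the measured compounds shown here, with no step bearing on it, the expectation in this assay is for no step beyond the scatter, no change at the digits printed from compound 3 to compound 4 (within the scatter). Compound 4 is therefore estimated at 650 nM, with a range from 250 nM to 1700 nM.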

Compound 4, half-maximal inhibitory concentration: 110 nM
Beside the measured number, compound 4's estimate is 5.9-fold (0.77 log units) above it; the whole stated range lies above it.
By their numbers in this assay, from the lowest: compound 2; then compound 4; then compound 3; then compound 1.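

The aryl group on the saturated chain carbon is not a silent place in this assay: 2-fluoro-5-methoxyphenyl in place of phenyl gives a step beyond the scatter, a 5.9-fold lower number from compound 3 to compound 4 (0.77 log units; beyond the scatter). The entering group brings a fluorine and a methoxy group together, so this step belongs to the pair and cannot be divided between them. Nothing measured here gives a reason for the step.

Open, going by these compounds, is whether the fluorine or the methoxy group alone accounts for the step, and whether an ethoxy group in place of methoxy, or an amine on the same aryl ring, would move the number further. Also open, on these data alone, is whether the same aryl change on the 1,3-thiazol-2-yl sulfonamide of compound 2 would give a step of similar size.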